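The compounds below may be only part of what the source reports. "The series", "measured", "known", "first", "only" and "open" are said of these compounds alone.

Measured so far, in a functional assay on MCF7 cells (Homo sapiens) for antiproliferative activity, read by MTT assay, with a stated time of 24 h; on this read-out higher numbers stand for weaker inhibition and lower numbers for stronger inhibition:

compound 1, `O=[N+]([O-])c1ccc(S(=O)(=O)n2c(-c3cn(-c4ccccc4)nc3-c3ccc(F)cc3)nc3ccccc32)cc1`: 1370 nM
compound 2, `O=S(=O)(c1ccc(F)cc1)n1c(-c2cn(-c3ccccc3)nc2-c2ccc(F)cc2)nc2ccccc21`: 3670 nM
compound 3, `O=[N+]([O-])c1ccc(S(=O)(=O)n2c(-c3cn(-c4ccccc4)nc3-c3ccc(C(F)(F)F)cc3)nc3ccccc32)cc1`: 1130 nM

Compound 1 and compound 2 differ by one change, (fluoro in place of nitro on an aromatic carbon), and this gave a 2.7-fold higher number from compound 1 to compound 2 (0.43 log units; beyond the scatter). Compound 1 and compound 3 share the rest of the molecule and differ only by trifluoromethyl in place of fluoro on an aromatic carbon, with a 1.2-fold lower number from compound 1 to compound 3 (0.08 log units; within the scatter), so compound 1 and compound 3 are not separated on this read-out. Against compound 2 the numbers of compound 1 and compound 3 are both lower, the gap to compound 3 being the larger of the two.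

Compound 4, `O=S(=O)(c1ccc(F)cc1)n1c(-c2cn(-c3ccccc3)nc2-c2ccc(C(F)(F)F)cc2)nc2ccccc21`, is not yet measured in this assay. It stands to compound 3 as compound 2 stands to compound 1: the change is fluoro in place of nitro on an aromatic carbon, and the place where it is made is described in the same words for both pairs, so this is the same change on the core of compound 3 rather than on the core of compound 1. Going by the values given here, the only comparison available for this change is the single step from compound 1 to compound 2, so the expectation for compound 4 rests on one pair and carries the uncertainty of a single measurement on each side.

Carrying that step over, compound 4 is expected to sit a 2.7-fold higher number from compound 3 to compound 4 (0.43 log units; beyond the scatter) from compound 3, because the same change gave a 2.7-fold higher number from compound 1 to compound 2 (0.43 log units; beyond the scatter). On that basis compound 4 is estimated at 3050 nM in this assay, with a range of about 1800 nM to 5500 nM.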

Compound 4, half-maximal inhibitory concentration: 3120 nM
Compound 4: middle estimate off by 1.0-fold (0.01 log units), on the low side, within the range that was stated.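

Exchanging 4-nitrophenyl for 4-fluorophenyl gives a 2.8-fold higher number from compound 3 to compound 4 (0.44 log units; beyond the scatter) in this assay, and this step carries over from one core to the other: the same change on two cores in this assay, a 2.7-fold higher number (0.43 log units; beyond the scatter) from compound 1 to compound 2 and a 2.8-fold higher number (0.44 log units; beyond the scatter) from compound 3 to compound 4, 1.0-fold (0.01 log units) apart, within the scatter of two such steps. Trifluoromethyl in place of fluoro gives a 1.2-fold lower number from compound 2 to compound 4 (0.07 log units; within the scatter), which leaves that pair unseparated on this read-out, and this near-absence of a step also holds on both cores: the same change on two cores in this assay, a 1.2-fold lower number (0.08 log units; within the scatter) from compound 1 to compound 3 and a 1.2-fold lower number (0.07 log units; within the scatter) from compound 2 to compound 4, 1.0-fold (0.01 log units) apart, within the scatter of two such steps. Going by these compounds alone, these four compounds therefore behave as a closed square in which each change reads the same whichever form of the other site is present, but that rests on only two cores differing at a single site, with one pair per core, and it does not show that either step would hold on a core altered elsewhere or in another assay.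

As far as these compounds go, the sulfonyl-bearing aromatic ring is represented only by its nitro and fluoro forms and the other varied ring only by its fluoro and trifluoromethyl forms, so it remains open how a nitrile, an amine or a carboxylic acid at either site would read. The rest of the shared core is identical in all four compounds, which leaves its contribution to the numbers undefined.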